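An Enyne Chain on a Vanilloid Amide

A few compounds are considered here, and "the series" means these few. Any claim that something is new, unique, unknown or untested is made for them only; others in the source may bear on it.

Three amides built on one shared core were tested in a functional assay on HEK293 cells with transient receptor potential cation channel subfamily V member 1 (Homo sapiens) as the target; on this read-out lower numbers stand for an effect already at smaller amounts and higher numbers for an effect only at larger amounts of compound. Compound 1 `COc1cc(CNC(=O)/C=C(\C)CCC=C(C)C)ccc1O` gives 39.8 nM, compound 2 `CCCCCCCC/C=C\CCCCCCCCCCC(=O)NCc1ccc(O)c(OC)c1` gives 3.16 nM, and compound 3 `CCCCCCCCC#CCCCCCCCC(=O)NCc1ccc(O)c(OC)c1` gives 12.6 nM. Compound 3 therefore stands second highest of the three, with compound 1 higher and compound 2 lower, both gaps beyond the usual scatter.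

Compound 4 `CCCCCC/C=C/C#CCCCCCCCC(=O)NCc1ccc(O)c(OC)c1` has not yet been measured. It differs from compound 3 by a group of 8 heavy atoms (8 carbon; no ring) in place of a group of 8 heavy atoms (8 carbon; no ring), on a triple-bonded carbon. For the measured compounds named here, no measured pair shows this exact change, so the three values alone guide the expectation. Because compound 2 gives 3.16 nM, a modest shift toward lower numbers, still within the scatter, is expected. The step from compound 3 to compound 4 in this assay is estimated at a 1.4-fold lower number from compound 3 to compound 4 (0.15 log units; within the scatter). Compound 4 is expected at 9 nM, from 3 nM to 30 nM.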

Compound 4, half-maximal effective concentration: 1.26 nM
Compound 4: middle estimate off by 7.1-fold (0.85 log units), on the high side, and the stated range ends above it.
By their numbers in this assay, from the lowest: compound 4; then compound 2; then compound 3; then compound 1.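

At this triple-bonded carbon, replacing octyl with a group of the same 8 heavy atoms that carries 1 double bond outside aromatic rings gives a 10-fold lower number from compound 3 to compound 4 (1.00 log units; beyond the scatter) in this assay. This position therefore responds strongly to a change that leaves the heavy-atom count, the lack of a ring and the hydrogen-bond counts as they were. Nothing available explains why the number falls.

Going by these compounds, whether the size of this step holds for a longer chain, a shorter chain or a phenyl ring in this place remains open.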